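Hydrogen in Place of Chloro: What to Expect

A few compounds are considered here, and "the series" means these few. Any claim that something is new, unique, unknown or untested is made for them only; others in the source may bear on it.

Compound 2 `CC(C(=O)N1CCN(c2ccc(Cl)cc2)CC1)N1C(=O)CCC1=O` stands at the top of the three numbers in a functional assay on the whole organism (strain Swiss) with Mus musculus as the target, in the maximal electroshock model, with a stated time of 0.25 h, at a dose of 300 mg/kg by the intraperitoneal route (a lower number here means a weaker effect, a higher number a stronger effect of the compound at the dose given), where compound 2 gives 100%. Compound 1 `CCC(C(=O)N1CCN(c2ccc(Cl)cc2)CC1)N1C(=O)CCC1=O` gives 0% and compound 3 `CC(C(=O)N1CCOCC1)N1C(=O)CCC1=O` gives 0%. For the measured compounds named here, the only one-place step among them, a number 100 percentage points higher from compound 1 to compound 2 (beyond the scatter), concerns a saturated chain carbon and not the aromatic ring. Compound 4 `CC(C(=O)N1CCN(c2ccccc2)CC1)N1C(=O)CCC1=O` differs from compound 2 by hydrogen in place of chloro on an aromatic carbon. Going by the values given here, no measured step touches the six-membered aromatic ring, so nothing in the data speaks directly to the size of this change in this assay. Compound 3, which has no such aromatic ring, gives 0% while compound 2 gives 100%, and that is all the two values show; compound 4 keeps the aromatic ring. Compound 4 is expected to keep much of the effect, at 70% with a range from 20% to 100%. The estimated step of a number 30 percentage points lower from compound 2 to compound 4 (beyond the scatter) is a modest fall, possibly within the scatter.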

Compound 4, a percentage reported as activity, at one dose (the size of the read-out at that dose, not a potency): 100%
For compound 4 the middle estimate is 30 percentage points below the measured one; the range from low to high includes it.
By their numbers in this assay, from the lowest: compounds 1 and 3 (each within the scatter of the next); then compounds 2 and 4 (each within the scatter of the next).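

In this assay the chloro on the six-membered aromatic ring proves dispensable at this dose: the change to hydrogen gives no change at the digits printed from compound 2 to compound 4 (within the scatter). The earlier compounds shown here offered no step at this ring, and the only one they did offer, on the saturated chain carbon, was a number 100 percentage points higher from compound 1 to compound 2 (beyond the scatter), so in this small set the read-out responds to that chain carbon but not to this 4-chlorophenyl to phenyl change. No measurement at hand accounts for this tolerance of the change.

As far as these compounds go, compound 2 at 100% and compound 4 at 100% are each read at a single dose, so whether the two would separate at lower doses stays open. Also open, from the compounds shown here alone, is how a methoxy group, an amine or a carboxylic acid would read at the same place on the ring.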